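The source may hold more compounds than are shown below. What is called first, only, known or untested is meant among the compounds shown, and "the series" means these compounds.

Compound 1 `Cc1[nH]c2ccccc2c(=O)c1Cc1ccccc1`: 1.93
Compound 2 `COc1ccc2[nH]c(C)c(Br)c(=O)c2c1`: 1.62

Both numbers come from a physicochemical assay for lipophilicity, at pH 7.4; on this read-out lower numbers stand for lower lipophilicity and higher numbers for higher lipophilicity. Of the two, compound 2 stands lowest, and compound 1 lies higher by more than the usual scatter. Compound 3 `Cc1[nH]c2ccc(Cl)cc2c(=O)c1Br` has not yet been measured. It shares the core of compound 2 and differs in a single place: chloro in place of methoxy on an aromatic carbon. The two measured compounds differ in more than one place, so they give no direct guide to the size of this step. Going by the structural change alone, a rise beyond the scatter is expected. The estimated change is a number 0.58 log units higher from compound 2 to compound 3 (beyond the scatter). In this assay, the expected value for compound 3 is 2.2, with an estimated range from 1.8 to 2.6.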

Compound 3, distribution coefficient: 2.02
Beside the measured number, compound 3's estimate is 0.18 log units above it, and the stated range covers the measured number.
By their numbers in this assay, from the lowest: compound 2; then compounds 1 and 3 (each within the scatter of the next).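

Going by these compounds alone, putting chloro in place of methoxy on this aromatic carbon gives the first direct reading of a single change on the shared core: in this assay, the swap gives a number 0.40 log units higher from compound 2 to compound 3 (beyond the scatter), and the rest of the structure stays the same. Compounds 1 and 2 differ in more than one place, so their gap could not isolate the effect of any one group. This single pair gives a size for the change at this position, but nothing shown explains why the number moves in this direction.

Open questions remain about how an amine, a carboxylic acid or a longer chain such as ethoxy at the same carbon would read in this assay. On these data alone, whether the same swap would give a similar step on another core also remains unknown.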